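The source may hold more compounds than are shown below. What is called first, only, known or untested is meant among the compounds shown, and "the series" means these compounds.

Measured compounds:
Compound 1, `COc1ccc(-c2cc(N)c(C(=O)c3cc(OC)c(OC)c(OC)c3)s2)cc1OC`, 72 nM
Compound 2, `COc1cc(C(=O)c2sc(-c3ccc(Cl)c(Cl)c3)cc2N)cc(OC)c1OC`, 400 nM

In a functional assay on FM3A cells (Mus musculus) for antiproliferative activity (on this read-out lower numbers stand for stronger inhibition and higher numbers for weaker inhibition), compound 1 gives the lowest of the two numbers; compound 2 gives a higher number, a 5.6-fold higher number from compound 1 to compound 2 (0.74 log units; beyond the scatter). Compound 3, `COc1cc(C(=O)c2sc(-c3ccsc3)cc2N)cc(OC)c1OC`, has not been measured. It differs from compound 1 in one place: thiophen-3-yl in place of 3,4-dimethoxyphenyl on an aromatic carbon. Within the data shown here, only one step bears on this change, the swap of the same group from compound 1 to compound 2, which raised the number beyond the scatter. A smaller ring entering at the same place is expected to cost potency again, with a step like a 4.2-fold higher number from compound 1 to compound 3 (0.62 log units; beyond the scatter). Compound 3 is therefore estimated at 300 nM, within 80 nM to 1500 nM.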

Compound 3, half-maximal inhibitory concentration: 3.7 nM
For compound 3 the middle estimate is 81-fold (1.91 log units) above the measured one; the measured number lies below the stated range.
By their numbers in this assay, from the lowest: compound 3; then compound 1; then compound 2.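

In this assay, thiophen-3-yl in place of 3,4-dimethoxyphenyl gives a 19-fold lower number from compound 1 to compound 3 (1.29 log units; beyond the scatter) and so moves the number the opposite way from the 3,4-dichlorophenyl swap. Set against 3,4-dichlorophenyl, the same ring gives a 110-fold lower number from compound 2 to compound 3 (2.03 log units; beyond the scatter) and shows how widely the number can swing with the group at this place. Nothing available here explains the swing. As far as these compounds go, whether ring size or the ring sulfur matters more stays open. A plain phenyl or a furan-3-yl at this place could help separate the two.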